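The compounds below may be only part of what the source reports. "The series", "measured", "known", "first", "only" and "open" are said of these compounds alone.

Measured so far in a functional assay on HT-29 cells (Homo sapiens) for cytotoxicity, read by MTT assay, with a stated time of 72 h; on this read-out lower numbers stand for stronger inhibition and higher numbers for weaker inhibition:

- compound 1, `CCN(CC)CCNc1nc(-c2ccc(NC(=O)Nc3ccccc3Cl)cc2)nc2c(Cl)c(Cl)sc12`: 550 nM
- compound 2, `CCN(CC)CCNc1nc(-c2ccc(NC(=O)Nc3ccccc3Cl)cc2)nc2ccsc12`: 620 nM
- compound 3, `CCN(CC)CCNc1nc(-c2ccc(NC(=O)Nc3ccc(Cl)cc3Cl)cc2)nc2c(Cl)c(Cl)sc12`: 1140 nM

Compound 1 and compound 2 carry the same side groups on two different cores; the difference between the two cores is not broken down here. In this assay the values of compound 1 and compound 2 lie within the scatter of each other, so nothing can be said about an order between them.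

Compound 1 and compound 3 differ in one place only: chloro in place of hydrogen on an aromatic carbon. This change gives a 2.1-fold higher number from compound 1 to compound 3 (0.32 log units; beyond the scatter), a modest step that nonetheless lies beyond the scatter.

Compound 4, `CCN(CC)CCNc1nc(-c2ccc(NC(=O)Nc3ccc(Cl)cc3Cl)cc2)nc2ccsc12`, has not yet been measured. It stands to compound 2 exactly as compound 3 stands to compound 1: chloro in place of hydrogen on an aromatic carbon. The surroundings of the place are the same word for word in both pairs, so this is the same change, made on the core of compound 2 instead of the core of compound 1.

With one measured occurrence of the change to rest on, the step from compound 2 to compound 4 is expected to be about a 2.0-fold higher number from compound 2 to compound 4 (0.30 log units; within the scatter), taking its size from a 2.1-fold higher number from compound 1 to compound 3 (0.32 log units; beyond the scatter). Among the compounds with values here, since only one prior example exists, the range is kept wide. Compound 4 is therefore estimated at 1250 nM in this assay, with the expected range running from 600 nM to 2600 nM.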

Compound 4, half-maximal inhibitory concentration: 1940 nM
The estimate for compound 4 lay 1.6-fold (0.19 log units) below the measured number; the measured number falls inside the stated range.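

In this assay, the change from 2-chlorophenyl to 2,4-dichlorophenyl, with the new chloro para to a large group, gives a 3.1-fold higher number from compound 2 to compound 4 (0.50 log units; beyond the scatter), a step beyond the scatter in the same direction as the one seen earlier on the other core. The two steps therefore agree in direction, and their sizes cannot be told apart, so on these two cores the change can be carried from one to the other as a single modest step towards higher numbers, with no sign that the core alters it: the same change on two cores in this assay, a 2.1-fold higher number (0.32 log units; beyond the scatter) from compound 1 to compound 3 and a 3.1-fold higher number (0.50 log units; beyond the scatter) from compound 2 to compound 4, 1.5-fold (0.18 log units) apart, within the scatter of two such steps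

Within the data shown here, this does not show that the step is larger on one core than on the other, and with only two pairs, one place on the ring and one read-out, it does not establish a rule for any further core or explain how the change acts.

Still open, going by these compounds, is whether a group other than chloro at the same place, such as fluoro, methyl or methoxy, moves the number in the same direction on both cores. Also open, on these data alone, is whether the step holds when the diethylaminoethyl side chain gives way to a morpholine or a longer chain, or when the change is made on a third core.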